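From pyridin-2-yl to pyridin-4-yl on the shared core

A few compounds are considered here, and "the series" means these few. Any claim that something is new, unique, unknown or untested is made for them only; others in the source may bear on it.

In a functional assay on MCF7 cells (Homo sapiens) for cytotoxicity, read by MTT assay, with a stated time of 48 h (a lower number here means a stronger inhibitor, a higher number a weaker inhibitor), compound 1 (`COc1ccccc1-c1nnc(SCCn2c([N+](=O)[O-])cnc2C)o1`) gives 10800 nM and compound 2 (`Cc1ncc([N+](=O)[O-])n1CCSc1nnc(-c2ccccn2)o1`) gives 39100 nM as the higher of the two numbers, which makes compound 2 the weaker inhibitor of this pair. Compound 3 (`Cc1ncc([N+](=O)[O-])n1CCSc1nnc(-c2ccncc2)o1`) has the same atoms as compound 2, joined differently, with pyridin-4-yl in place of pyridin-2-yl on an aromatic carbon. Going by the values given here, the only measured step that bears on this is a 3.6-fold higher number from compound 1 to compound 2 (0.56 log units; beyond the scatter) and it is modest, at the same place but with 2-methoxyphenyl as the group that leaves. Among the compounds with values here, no measured pair compares two pyridinyl groups, so a step smaller than that one is expected, with little confidence in its direction. The estimated change is a 1.3-fold lower number from compound 2 to compound 3 (0.12 log units; within the scatter) in this assay and stays inside the scatter. For compound 3 the estimated value is 30000 nM within an expected range from 12000 nM to 70000 nM in this read-out.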

Compound 3, half-maximal inhibitory concentration: 12600 nM
Compound 3: the middle estimate sits 2.4-fold (0.38 log units) above what was measured; measured number inside the range.
By their numbers in this assay, from the lowest: compounds 1 and 3 (each within the scatter of the next); then compound 2.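

In this assay, this position tells apart two groups with the same atoms and the same counts: moving the ring nitrogen, with pyridin-4-yl in place of pyridin-2-yl on the aromatic carbon, is a step beyond the scatter (a 3.1-fold lower number from compound 2 to compound 3 (0.49 log units; beyond the scatter)). The weak result of compound 2 is therefore not shared by both pyridinyl groups shown, and replacing 2-methoxyphenyl no longer goes with a higher number beyond the scatter (a 1.2-fold higher number from compound 1 to compound 3 (0.07 log units; within the scatter)), which leaves compound 1 and compound 3 within the scatter of each other. No measurement at hand accounts for either step.

From the compounds shown here alone, whether pyridin-3-yl, a plain phenyl or an aminophenyl group at this place would group with compound 2 or with compound 1 and compound 3 stays open. Also open, going by these compounds, is how a longer chain in the linker of the shared core would affect these numbers.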